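This account rests on a few compounds, and the source may have more. Where it says the series, first, only, none or still open, it means among the compounds named here.

Compound 1 `CCS(=O)(=O)Nc1ccc(NC(=O)c2cccc(C(F)(F)F)c2)cc1OC` is measured in an ADME assay on RAW264.7 cells (Mus musculus) for cytotoxicity, read by MTT assay, with a stated time of 48 h (on this read-out lower numbers stand for stronger inhibition and higher numbers for weaker inhibition), where compound 1 gives 84800 nM. Of the two numbers shown, compound 1 holds the higher, with compound 3 `COc1cc(NC(=O)c2cccc(C(F)(F)F)c2)ccc1NS(=O)(=O)C(F)(F)F` nearest and the gap within the scatter: in this assay compound 3 gives 75200 nM. Compound 2 `CCS(=O)(=O)Nc1ccc(NC(=O)c2cc(C(F)(F)F)cc(C(F)(F)F)c2)cc1OC` reaches only a limit in this assay, > 250000 nM. The measured steps are an at least 2.9-fold higher number from compound 1 to compound 2 (0.46 log units; beyond the scatter) and a 1.1-fold lower number from compound 1 to compound 3 (0.05 log units; within the scatter). Compound 4 `CCS(=O)(=O)Nc1ccc(NC(=O)c2cccc(C(F)(F)F)c2)cc1F` differs from compound 1 by fluoro in place of methoxy on an aromatic carbon. Among the measured compounds shown here, neither measured step touches this position, and the one step beyond the scatter ends at a limit, so for compound 4 no step beyond the scatter is expected in this assay, a 1.1-fold higher number from compound 1 to compound 4 (0.03 log units; within the scatter). Compound 4 is therefore estimated at 90000 nM, between 35000 nM and 250000 nM.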

Compound 4, half-maximal inhibitory concentration: 119000 nM
Beside the measured number, compound 4's estimate is 1.3-fold (0.12 log units) below it; measured number inside the range.
By their numbers in this assay, from the lowest: compounds 3, 1 and 4 (each within the scatter of the next). At a limit, above all of these: compound 2.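

In this assay, fluoro in place of methoxy on this aromatic carbon, ortho to the (ethylsulfonyl)amino group, gives a 1.4-fold higher number from compound 1 to compound 4 (0.15 log units; within the scatter). This position therefore joins the sulfonyl sulfur as a place where a single change stays within the scatter, even though the methoxy group and its hydrogen-bond acceptor are gone. Only compound 2 stands at a limit, so this step, unlike the one ending there, is read between two numbers: the limit of > 250000 nM in this assay, at which 1 of the 4 values shown sits.

Still open, on these data alone, is how an amine, a hydroxyl or a longer alkoxy chain on this carbon would behave. As far as these compounds go, whether fluoro gives the same step on the trifluoromethylsulfonyl analogue, compound 3, also remains open.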